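Second chloro on the aryl ring of compound 2

This account rests on a few compounds, and the source may have more. Where it says the series, first, only, none or still open, it means among the compounds named here.

Compound 1 `CCN1CC[C@@]2(OC)OC(N)=C(C#N)[C@@H](c3ccccc3)[C@@H]2C1` gives 23400 nM in a functional assay on trachea (Cavia porcellus); on this read-out lower numbers stand for stronger inhibition and higher numbers for weaker inhibition. Compound 2 `CCN1CC[C@@]2(OC)OC(N)=C(C#N)[C@@H](c3ccc(Cl)cc3)[C@@H]2C1` gives 14900 nM, the lowest of the two numbers shown, yet within the scatter of compound 1, so no ranking is claimed. The change to compound 3 `CCN1CC[C@@]2(OC)OC(N)=C(C#N)[C@@H](c3ccc(Cl)cc3Cl)[C@@H]2C1` is chloro in place of hydrogen on an aromatic carbon, turning 4-chlorophenyl into 2,4-dichlorophenyl. Going by the values given here, the only step that bears on it is a 1.6-fold lower number from compound 1 to compound 2 (0.20 log units; within the scatter), a first chloro on the same ring. A shift of like size or none beyond the scatter is expected, a 1.5-fold lower number from compound 2 to compound 3 (0.17 log units; within the scatter). Compound 3 is estimated at 10000 nM, range 3500 nM to 30000 nM.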

Compound 3, half-maximal inhibitory concentration: 27100 nM
Beside the measured number, compound 3's estimate is 2.7-fold (0.43 log units) below it; the range from low to high includes it.
By their numbers in this assay, from the lowest: compounds 2, 1 and 3 (each within the scatter of the next).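

In this assay, chloro ortho to a large group gives a 1.8-fold higher number from compound 2 to compound 3 (0.26 log units; within the scatter), so this position, first tested here, shows no gain from a second chloro on the ring. With both chloro groups counted, 2,4-dichlorophenyl gives a 1.2-fold higher number from compound 1 to compound 3 (0.06 log units; within the scatter), so the series still shows no separation from the unsubstituted phenyl ring. No evidence on this result is available.

Still open, from the compounds shown here alone, is whether a methoxy group or a carboxylic acid on this ring would move the number beyond the scatter. The same holds for a longer chain in place of the ethyl group.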